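The source may report more compounds than this note shows. Statements on the series, on what has been measured and on what is new or still open speak of the compounds shown alone.

Compound 1 `O=c1c2cnn(-c3ccc(F)cc3)c2ncn1CC1(O)CCN(Cc2ccccc2)CC1`, in an assay on Sf21 cells for inhibition of ubiquitin carboxyl-terminal hydrolase 7 (Homo sapiens), read by spectrophotometry, with stated times of 30 min and 2 h (on this read-out higher numbers stand for weaker inhibition and lower numbers for stronger inhibition), compound 1 gives "not determined" (no result reported).
Compound 2 `O=c1c2cnn(-c3ccc(F)cc3)c2ncn1CC1(O)CCN(Cc2ccc(Br)cc2)CC1`, in this assay compound 2 gives 6700 nM.
Compound 3 `O=c1c2cnn(-c3ccc(F)cc3)c2ncn1CC1(O)CCN(Cc2ccc(C(F)(F)F)cc2)CC1`, in this assay compound 3 gives "not determined" (no result reported).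

Compound 3 stands without a number, as does compound 1; among the three, only compound 2 has a measured value in this assay, and it is a weak one. Going by the values given here, no pair of measured compounds differs in a single place, so no step size is known.

Compound 4 `COC(=O)c1ccc(CN2CCC(O)(Cn3cnc4c(cnn4-c4ccc(F)cc4)c3=O)CC2)cc1` differs from compound 3 by methoxycarbonyl in place of trifluoromethyl on an aromatic carbon. Among the compounds with values here, with no comparable step to lean on, the size and direction of this change cannot be foreseen; it may well stay within the scatter.

Compound 4 is expected to land near the value of compound 2 6700 nM, estimated at 8000 nM within 2000 nM to 30000 nM.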

Compound 4, half-maximal inhibitory concentration: 4500 nM
Estimate against measurement, compound 4: 1.8-fold (0.25 log units) above; the measured number falls inside the stated range.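

In this assay, methoxycarbonyl and bromo can now be compared on this aromatic carbon, para to a large group. With a 1.5-fold lower number from compound 2 to compound 4 (0.17 log units; within the scatter), the two groups cannot be told apart here, even though only methoxycarbonyl brings hydrogen-bond acceptors. Nothing available explains this result.

Compound 1 and compound 3 carry no number, so steps involving them cannot be read, and the hydrogen and trifluoromethyl cases stay undefined. From the compounds shown here alone, whether a carboxylic acid or an amine on this carbon would read differently remains open.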